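Swapping a benzylselanyl group for methylsulfanyl on a bis-acyl amidine

The source may report more compounds than this note shows. Statements on the series, on what has been measured and on what is new or still open speak of the compounds shown alone.

Measured compounds:
compound 1, `CS/C(=N\C(=O)c1ccno1)NC(=O)c1ccno1`, 16900 nM;
compound 2, `O=C(/N=C(/NC(=O)c1ccno1)[Se]Cc1ccccc1)c1ccno1`, 7800 nM;
compound 3, `O=C(/N=C(/NC(=O)c1cc(-c2ccccc2)nc2ccccc12)[Se]Cc1ccccc1)c1cc(-c2ccccc2)nc2ccccc12`, 8460 nM.

All three were tested in an ADME assay on MCF-10A cells (Homo sapiens) for cytotoxicity, read by MTT assay, with a stated time of 72 h; on this read-out higher numbers stand for weaker inhibition of growth and lower numbers for stronger inhibition of growth. Compound 4, `CS/C(=N\C(=O)c1cc(-c2ccccc2)nc2ccccc12)NC(=O)c1cc(-c2ccccc2)nc2ccccc12`, has not yet been measured there. It is related to compound 3 by a group of 2 heavy atoms (1 carbon, 1 sulfur; no ring) in place of a group of 8 heavy atoms (7 carbon, 1 selenium; one six-membered aromatic ring of carbon only), on a carbon with a double bond to nitrogen. The same change joins compound 2 to compound 1, as a group of 2 heavy atoms (1 carbon, 1 sulfur; no ring) in place of a group of 8 heavy atoms (7 carbon, 1 selenium; one six-membered aromatic ring of carbon only), on a carbon with a double bond to nitrogen, on an identical place, and there it gave a 2.2-fold higher number from compound 2 to compound 1 (0.34 log units; beyond the scatter). The difference between the core of compound 2 and the core of compound 3 is not broken down here, yet compound 2 and compound 3 show values close to each other in this assay. The step expected from compound 3 to compound 4 is a 2.0-fold higher number from compound 3 to compound 4 (0.30 log units; within the scatter), about as large as the measured one, because the change from compound 2 to compound 1 gave a 2.2-fold higher number from compound 2 to compound 1 (0.34 log units; beyond the scatter). Among the compounds with values here, with only one earlier example, this rests on thin ground. Compound 4 is therefore estimated at 17000 nM, most likely between 8000 nM and 36000 nM.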

Compound 4, concentration for 50% growth inhibition: 40 nM
Compound 4: the middle estimate sits 430-fold (2.63 log units) above what was measured, outside the stated range (below it).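

In this assay, putting methylsulfanyl in place of the benzylselanyl group gave a 210-fold lower number from compound 3 to compound 4 (2.33 log units; beyond the scatter), so the result on one core did not carry over to the other, not even in direction: the same change on two cores in this assay, a 2.2-fold higher number (0.34 log units; beyond the scatter) from compound 2 to compound 1 and a 210-fold lower number (2.33 log units; beyond the scatter) from compound 3 to compound 4, 460-fold (2.66 log units) apart, beyond the scatter of two such steps

For these two pairs, the outcome of the change depends on the core that carries it, so a single earlier step is a poor guide to the next core. The data do not show which part of the core is responsible, and the reason for the gap stays unknown.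

Going by these compounds, it remains open whether a methylselanyl group on the core of compound 4 would behave like methylsulfanyl or like benzylselanyl. A benzylsulfanyl group or an amine on that same carbon is equally untested in what is shown.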